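This account rests on a few compounds, and the source may have more. Where it says the series, first, only, none or still open, it means among the compounds named here.

Compound 3 `CC(C)OC(=O)N1CCN(C(=O)c2nc(Nc3cc(C4CC4)[nH]n3)c3cc(Cl)ccc3n2)C[C@H]1C` gives 78.6% in an ADME assay on S9 fraction from liver (Rattus norvegicus), read by LC-MS, with a stated time of 60 min, at 37 degrees C (a higher number here means that more of the compound is left, a lower number that less of the compound is left), the highest of the three numbers measured; compound 1 `CCCCCOC(=O)N1CCN(C(=O)c2nc(Nc3cc(C4CC4)[nH]n3)c3cc(Cl)ccc3n2)C[C@H]1C` gives 63.9% and compound 2 `CC(OC(=O)C(C)C)OC(=O)N1CCN(C(=O)c2nc(Nc3cc(C4CC4)[nH]n3)c3cc(Cl)ccc3n2)C[C@H]1C` gives 11%. Compound 4 `CC(OC(=O)N1CCN(C(=O)c2nc(Nc3cc(C4CC4)[nH]n3)c3cc(Cl)ccc3n2)C[C@H]1C)OC(=O)C(C)(C)C` differs from compound 3 in one place: ((tert-butyl)carbonyl)oxy in place of methyl on a saturated chain carbon bound to an oxygen next to a carbonyl group and a saturated chain carbon. The step that bears on this most is a number 67.6 percentage points higher from compound 2 to compound 3 (beyond the scatter), a large rise when (isopropylcarbonyl)oxy is replaced by methyl; compound 4 takes the reverse direction, with ((tert-butyl)carbonyl)oxy entering instead. The step of a number 52.9 percentage points lower from compound 1 to compound 2 (beyond the scatter) points the same way. Compound 4 is therefore expected to show a large drop in this assay, a number 63.6 percentage points lower from compound 3 to compound 4 (beyond the scatter). Compound 4 is estimated at 15%, within 3% to 40%.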

Compound 4, percent of the compound remaining: 66.3%
The estimate for compound 4 lay 51.3 percentage points below the measured number, outside the stated range (above it).
By their numbers in this assay, from the lowest: compound 2; then compounds 1 and 4 (each within the scatter of the next); then compound 3.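

In this assay, an ester-bearing group at this place does not by itself give a number as low as that of compound 2: ((tert-butyl)carbonyl)oxy in place of methyl brings only a modest change (a number 12.3 percentage points lower from compound 3 to compound 4 (beyond the scatter)). One methyl in place of hydrogen on the saturated chain carbon bound to a carbonyl carbon and two saturated chain carbons gives a large step (a number 55.3 percentage points higher from compound 2 to compound 4 (beyond the scatter)), while the replacement of pentyl by 1-(((tert-butyl)carbonyl)oxy)ethyl gives no clear change (a number 2.4 percentage points higher from compound 1 to compound 4 (within the scatter)). No measurement shown explains this difference.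

On these data alone, it remains open whether a benzoyloxy group at this place would stand with compound 2 or compound 4. The compounds shown also leave open what the result would be with a longer chain on that carbonyl.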